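A few compounds are considered here, and "the series" means these few. Any claim that something is new, unique, unknown or untested is made for them only; others in the source may bear on it.

Measured so far in an assay on isolated protein for inhibition of Amine oxidase [flavin-containing] A (Homo sapiens), read by fluorescence; on this read-out higher numbers stand for weaker inhibition and lower numbers for stronger inhibition:
- compound 1, `N#Cc1cc2[nH]c(-c3ccccc3)c(Cl)c2cc1C#N`: 121 nM
- compound 2, `Cn1c(-c2ccccc2)c(Cl)c2cc(C#N)c(C#N)cc21`: 142 nM

The two compounds share one core and differ only at the aromatic nitrogen, where compound 2 carries a methyl in place of a hydrogen. Compound 2 stands beside compound 1 on these numbers; the step of a 1.2-fold higher number from compound 1 to compound 2 (0.07 log units; within the scatter) lies within the scatter, so the two cannot be told apart with confidence.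

Compound 3, `Cn1c(-c2cccs2)c(Cl)c2cc(C#N)c(C#N)cc21`, keeps the methyl of compound 2 and changes the ring attached to the core: thiophen-2-yl in place of phenyl on an aromatic carbon. Among the measured compounds shown here, no measured step touches this position; the only step in hand, a 1.2-fold higher number from compound 1 to compound 2 (0.07 log units; within the scatter), concerns the nitrogen and says nothing directly about swapping the phenyl. That step was flat, which at least shows the core tolerates a small change without losing inhibition. With nothing more to go on, the expected step for compound 3 is a 1.1-fold higher number from compound 2 to compound 3 (0.02 log units; within the scatter), that is, none beyond the scatter. Compound 3 is therefore estimated at 150 nM in this assay, in a range of 60 nM to 400 nM.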

Compound 3, half-maximal inhibitory concentration: 35 nM
Compound 3: middle estimate off by 4.3-fold (0.63 log units), on the high side; measured number below the stated range.
By their numbers in this assay, from the lowest: compound 3; then compounds 1 and 2 (each within the scatter of the next).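

In this assay, among the compounds shown here, the ring on this aromatic carbon turns out to matter: thiophen-2-yl in place of phenyl gives a 4.1-fold lower number from compound 2 to compound 3 (0.61 log units; beyond the scatter), a step beyond the scatter and towards stronger inhibition, whereas the only earlier step, a 1.2-fold higher number from compound 1 to compound 2 (0.07 log units; within the scatter), at the aromatic nitrogen, stayed within it. This is therefore the first place on the shared core where inhibition responds to a change, and the response is modest in size. The swap alters two things at once, going from a six-membered ring of carbon only to a five-membered ring holding a sulfur, and no measurement here explains the stronger inhibition.

On these data alone, it remains open whether the sulfur or the smaller ring size counts, which a furan-2-yl or thiophen-3-yl ring at the same carbon could help to separate, and whether a pyridin-2-yl ring or a phenyl carrying an amine would move the number in either direction. Also open, as far as these compounds go, is whether thiophen-2-yl gives the same step when hydrogen replaces the methyl on the ring nitrogen.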